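This account rests on a few compounds, and the source may have more. Where it says the series, first, only, none or still open, it means among the compounds named here.

Working notes on the series. In an assay on isolated protein (Oryctolagus cuniculus) with Thromboxane-A synthase (Homo sapiens) as the target, tested at 1 uM (a lower number here means less inhibition, a higher number more inhibition at the concentration tested (going by the name of the read-out)), compound 1 `CCCn1nc(-c2cccnc2)c2ccccc2c1=O` gives 86%, and compound 2 `O=c1c2ccccc2c(-c2cccnc2)nn1Cc1cccc(Cl)c1` gives 95%. Going by the values given here, compound 1 stands lowest of the two numbers, though the only measured step, a number 9 percentage points higher from compound 1 to compound 2 (within the scatter), is within the scatter. Compound 3 `O=c1c2ccccc2c(-c2cccnc2)nn1CCSc1ncccn1` differs from compound 1 by (pyrimidin-2-yl)sulfanyl in place of methyl on a saturated chain carbon, two bonds along the chain from an aromatic nitrogen. Among the compounds with values here, the only step measured so far on this chain is a number 9 percentage points higher from compound 1 to compound 2 (within the scatter), which suggests a change there moves the inhibition little. No step beyond the scatter is expected for compound 3, and the expected step is a number 2 percentage points higher from compound 1 to compound 3 (within the scatter). Compound 3 is estimated at 88%, in the range 72% to 98%.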

Compound 3, a percentage reported as inhibition, at one concentration (the size of the read-out at that concentration, not a potency): 86%
Compound 3: the middle estimate sits 2 percentage points above what was measured, and the stated range covers the measured number.
By their numbers in this assay, from the lowest: compounds 1, 3 and 2 (each within the scatter of the next).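

In this assay the saturated chain carbon two bonds along the chain from an aromatic nitrogen accepts (pyrimidin-2-yl)sulfanyl in place of methyl, with no change at the digits printed from compound 1 to compound 3 (within the scatter) here. Putting ((pyrimidin-2-yl)sulfanyl)methyl in place of 3-chlorophenyl gives a number 9 percentage points lower from compound 2 to compound 3 (within the scatter) as well, so all three chain ends now lie within the scatter of one another. No measurement at hand accounts for this flat picture.

Going by these compounds, whether an amine, a carboxylic acid or a longer chain at this position would hold the inhibition remains open. Also open, on these data alone, is whether these three compounds would separate at a lower test concentration.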